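The compounds below may be only part of what the source reports. "The series", "measured", "known", "first", "only" and "open" are said of these compounds alone.

Compound 1 `Clc1cccc(-c2cnc(Nc3ccc4[nH]ncc4c3)o2)c1`: > 100 uM; compound 2 `COc1cc(-c2cnc(Nc3ccc4[nH]ncc4c3)o2)ccc1Cl`: 80 uM.

Compound 1 gives only a limit of the assay, (the limit of > 100 uM in this assay, at which 1 of the 2 values shown sits), and not a number. Compound 2 holds the only number shown, standing in an ADME assay on MT4 cells (Homo sapiens) for cytotoxicity, read by WST assay (on this read-out higher numbers stand for lower toxicity in this test and lower numbers for higher toxicity in this test), at 80 uM. Compound 3 `Clc1ccc(-c2cnc(Nc3ccc4[nH]ncc4c3)o2)cc1Cl` differs from compound 2 by chloro in place of methoxy on an aromatic carbon. Among the measured compounds shown here, no measured pair shows such a change, and the expected step in this assay, a 1.1-fold higher number from compound 2 to compound 3 (0.05 log units; within the scatter), is estimated to be none beyond the scatter. Compound 3 is expected at 90 uM, in the range 40 uM to 200 uM.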

Compound 3, half-maximal toxic concentration: > 100 uM
Compound 3 gave a limit, no number; the forecaster's own chance of this, stated with the estimate: 40%; at least 1.1-fold (0.04 log units) between middle value and limit.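

In this assay, chloro in place of methoxy, on the aromatic carbon ortho to a chloro group, gives an at least 1.2-fold higher number from compound 2 to compound 3 (0.09 log units; that floor lies within the scatter). Compound 3 gives only a limit of the assay, > 100 uM, so the pair sets a floor for this change and not a size. The top of the read-out now holds most of the series: the limit of > 100 uM in this assay, at which 2 of the 3 values shown sit.

The step between compound 1 and compound 3 cannot be read, as both values are limits. As far as these compounds go, how far this change truly reaches stays open, as does what an amine or a hydroxyl on this carbon would do to the number.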